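The compounds below may be only part of what the source reports. "The series", "measured", "known", "first", "only" and "open" are said of these compounds alone.

Compound 1, `C[C@@H](NCC1CCN(CCCc2c[nH]c3ccc(-n4cnnc4)cc23)CC1)c1ccccc1`, is the strongest binder among the three compounds measured here. In an assay on CHO cells for displacement of a labelled ligand from 5-hydroxytryptamine receptor 1B (Homo sapiens) (on this read-out higher numbers stand for weaker inhibition and lower numbers for stronger inhibition), compound 1 gives 14 nM. Compound 3, `OC[C@H](NC1CCN(CCCc2c[nH]c3ccc(-n4ccnc4)cc23)CC1)c1ccccc1`, gives 100 nM in this assay, a higher number that sits beyond the scatter of compound 1. Compound 2, `c1ccc(C2CCCCN2C2CCN(CCCc3c[nH]c4ccc(-n5cnnc5)cc34)CC2)cc1`, gives 410 nM in this assay, the highest number of the three and the furthest from compound 1. None of these three pairs differs in a single place, so the individual values are all that can be read from them.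

Compound 4, `c1ccc2c(c1)CCC2NC1CCN(CCCc2c[nH]c3ccc(-n4cnnc4)cc23)CC1`, has not yet been measured in this assay. It differs from compound 1 as follows: (2,3-dihydro-1H-inden-1-yl)amino in place of ((1-phenylethyl)amino)methyl on a saturated ring carbon. Here the amine sits directly on the saturated ring carbon, while in compound 1 a methylene separates the two. Among the compounds with values here, no measured pair isolates this change, so the expectation rests on the general level of the series. A modest step toward a higher number is expected from compound 1 to compound 4, a 2.9-fold higher number from compound 1 to compound 4 (0.46 log units; beyond the scatter), though it may well stay within the scatter. Compound 4 is estimated at 40 nM, within a range from 10 nM to 160 nM.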

Compound 4, half-maximal inhibitory concentration: 280 nM
Estimate against measurement, compound 4: 7.0-fold (0.85 log units) below; the measured number lies above the stated range.
By their numbers in this assay, from the lowest: compound 1; then compound 3; then compounds 4 and 2 (each within the scatter of the next).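

In this assay, the exchange at this saturated ring carbon brings a 20-fold higher number from compound 1 to compound 4 (1.30 log units; beyond the scatter), a large step beyond the scatter, so the measured number here depends strongly on the group at this place. The step arises even though the group that leaves and the group that enters have the same counts of heavy atoms, hydrogen-bond donors and hydrogen-bond acceptors; what differs is the added five-membered ring, the missing methylene and the defined stereocentre, which only the leaving group has. No measurement given here explains the step.

This single step cannot show how much of it belongs to each of those differences. A (1-phenylethyl)amino group placed directly on the saturated ring carbon, or a (2,3-dihydro-1H-inden-1-yl)aminomethyl group, would leave open which one matters.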